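Trimming a Furan Ring Down to a Nitrile

The compounds below may be only part of what the source reports. "The series", "measured", "known", "first", "only" and "open" are said of these compounds alone.

Of the compounds shown here, three built on a shared fused core have been tested in an ADME assay on HEL cells (Homo sapiens) for cytotoxicity, with a stated time of 3 days; a higher number here means that more compound is tolerated, a lower number that less compound is tolerated. Compound 1 `C=Cc1ccc(-c2cc(C)c3ncc(CSCCc4ccccc4)n3c2)cc1` gives 20 ug/mL in this assay. Compound 2 `Cc1cc(-c2ccsc2)c2ncc(CSCc3ccccc3)n2c1` gives 100 ug/mL, and compound 3 `Cc1cc(-c2ccoc2)c2ncc(CSCCc3ccccc3)n2c1` gives 100 ug/mL. Compound 3 therefore stands level with compound 2 at the digits shown, the two of them together at the top of the three numbers, while compound 1 sits clearly lower; that gap to compound 1 is beyond the usual scatter, whereas the match with compound 2 lies within it.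

The next compound, compound 4 `Cc1cc(C#N)c2ncc(CSCCc3ccccc3)n2c1`, follows from compound 3 by one change: cyano in place of furan-3-yl on an aromatic carbon. Among the compounds with values here, no pair of measured compounds differs in this way, so there is no direct precedent within this set for how such a swap moves the tolerated concentration in this assay.

Compound 4 is expected to show a step of no change at the digits printed from compound 3 to compound 4 (within the scatter) that stays within the scatter, because compound 3 already gives 100 ug/mL and nothing measured here points to a lower tolerance for a smaller group. Compound 4 is therefore estimated at 100 ug/mL, with a likely range from 40 ug/mL to 200 ug/mL.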

Compound 4, minimum cytotoxic concentration: >= 20 ug/mL
Compound 4: no number, only a limit; the forecaster's own chance of this, stated with the estimate: 20%; the middle value lies beyond the limit too.
By their numbers in this assay, from the lowest: compound 1; then compounds 2 and 3 (each within the scatter of the next).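

In this assay, compound 4 gives >= 20 ug/mL, which is a limit and not a number. No step from compound 3 to compound 4 can be read from this result, because it gives only the following: the limit of >= 20 ug/mL in this assay, at which 1 of the 4 values shown sits.

The compounds shown leave open whether cyano in place of furan-3-yl on this aromatic carbon changes how much compound is tolerated.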